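Methyl for cyclopropyl on the ring amine nitrogen

The compounds below may be only part of what the source reports. "The series", "measured", "known", "first", "only" and "open" are said of these compounds alone.

Three compounds of the series have numbers in a functional assay on CCRF-CEM cells for antagonist activity at C-X-C chemokine receptor type 4 (Homo sapiens), read by calcium flux, with stated times of 25 min and 90 s; on this read-out higher numbers stand for weaker inhibition and lower numbers for stronger inhibition. Compound 1 `Cc1cnc(CN(C)C[C@H]2Cc3c(cccc3N3CCNCC3)CN2)c(C)c1` gives 21.4 nM in this assay. Compound 2 `CN(C[C@H]1Cc2c(cccc2N2CCN(C3CC3)CC2)CN1)[C@H]1CCCc2cccnc21` gives 23.5 nM in this assay. Compound 3 `CC(C)N(C[C@H]1Cc2c(cccc2N2CCNCC2)CN1)[C@H]1CCCc2cccnc21` gives 364 nM in this assay. Compound 2 therefore holds the second highest of the three numbers: the number of compound 1 lies within the scatter of it, so no order between these two can be claimed, while the number of compound 3 lies well above it, beyond the scatter.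

The next compound, compound 4 `CN1CCN(c2cccc3c2C[C@H](CN(C)[C@H]2CCCc4cccnc42)NC3)CC1`, is not yet measured in this assay. It differs from compound 2 in one place: methyl in place of cyclopropyl on an amine nitrogen in a ring. Going by the values given here, no measured pair isolates exactly this change. Compound 1, which carries no group on that ring nitrogen, and compound 2, which carries cyclopropyl there, sit within the scatter of each other, so the group on this nitrogen has so far made no difference beyond the scatter.

On that basis, the step from compound 2 to compound 4 is expected to be none beyond the scatter, a 1.1-fold higher number from compound 2 to compound 4 (0.03 log units; within the scatter). Compound 4 is thus estimated at 25 nM in this assay, with a range from 10 nM to 70 nM.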

Compound 4, half-maximal inhibitory concentration: 29.6 nM
Estimate against measurement, compound 4: 1.2-fold (0.07 log units) below; low and high end bracket the measured number.
By their numbers in this assay, from the lowest: compounds 1, 2 and 4 (each within the scatter of the next); then compound 3.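

In this assay, going by these compounds alone, the pair of compound 2 and compound 4 is the first to isolate the group on this ring nitrogen, and replacing 4-cyclopropylpiperazin-1-yl with 4-methylpiperazin-1-yl gives a step within the scatter (a 1.3-fold higher number from compound 2 to compound 4 (0.10 log units; within the scatter)). On this core and with this side chain, the ring nitrogen therefore accepts either cyclopropyl or methyl without a readable change in the number, even though the three-membered ring goes and the group shrinks from 3 heavy atoms to 1. No measurement shown gives a cause for this result or any property of either group at this position.

The compounds shown leave open whether a group of another kind on this nitrogen, such as a longer chain, an acetyl group or a chain ending in a carboxylic acid, would also stay within the scatter of compound 2. On these data alone, it also remains open whether the same exchange would read alike on the side chain of compound 3, which gives 364 nM in this assay.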